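Solubility notes on the series, compounds 1 to 3

A few compounds are considered here, and "the series" means these few. Any claim that something is new, unique, unknown or untested is made for them only; others in the source may bear on it.

Compound 1 `CNS(=O)(=O)c1ccc(-c2cnc(N)c(-c3ccc(OC)nc3)c2)cc1`: > 100 ug/mL
Compound 2 `COc1ccc(-c2cc(-c3ccc(NS(C)(=O)=O)cc3)cnc2N)cn1`: > 100 ug/mL

In a physicochemical assay for solubility, read by nephelometry, measured as kinetic solubility, at pH 2 (on this read-out higher numbers stand for higher solubility and lower numbers for lower solubility), compound 1 gives > 100 ug/mL, which is a limit of the assay. Compound 2 gives > 100 ug/mL, likewise a limit. The step that the two limits leave unreadable from compound 1 to compound 2 is therefore not readable, both values sitting at the limit of > 100 ug/mL in this assay, at which 2 of the 2 values shown sit. Compound 2 thus stands only at the limit, with no number below it. Compound 3 `COc1ccc(-c2cc(-c3ccc(C(F)(F)F)cc3)cnc2N)cn1` differs from compound 2 by trifluoromethyl in place of methanesulfonamido on an aromatic carbon. Going by the values given here, no measured step bears on this change, so the size of the step in this assay cannot be read from the series. The step is nonetheless expected at an at least 2.0-fold lower number from compound 2 to compound 3 (0.30 log units; that floor lies within the scatter). Compound 3 is estimated at 50 ug/mL, within 12 ug/mL to 150 ug/mL.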

Compound 3, solubility: > 100 ug/mL
Compound 3 ended at the assay's limit (the forecaster's own chance of this, stated with the estimate: 30%); at least 2.0-fold (0.30 log units) between middle value and limit.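

In this assay compound 3 gives > 100 ug/mL, a limit. No step among compound 1, compound 2 and compound 3 can be read: the limit of > 100 ug/mL in this assay, at which 3 of the 3 values shown sit.

Going by these compounds, whether methylsulfamoyl, methanesulfonamido and trifluoromethyl differ at all in this assay stays open.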